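Aryl replacement on the shared core: expected binding shift

The source may report more compounds than this note shows. Statements on the series, on what has been measured and on what is new or still open speak of the compounds shown alone.

Among the compounds with values here, compound 1 `Nc1nc(N/N=C/c2cncs2)nc2c1ncn2[C@@H]1O[C@H](CO)[C@@H](O)[C@H]1O` is measured in an assay on CHO-K1 cells for displacement of a labelled ligand from adenosine receptor A1 (Homo sapiens), read by scintillation counting, with a stated time of 60 min (a lower number here means a stronger inhibitor, a higher number a weaker inhibitor), at 22 nM, the higher of the two numbers known. Its nearest neighbour, compound 2 `Nc1nc(N/N=C/c2ccc(-c3ccc(Br)cc3)o2)nc2c1ncn2[C@@H]1O[C@H](CO)[C@@H](O)[C@H]1O`, gives 4.5 nM in this assay; the two values differ beyond the scatter, so compound 2 is the stronger of the pair. Within the data shown here, no step between measured compounds differing in one place is available. Compound 3 `CCCOc1ccc(/C=N/Nc2nc(N)c3ncn([C@@H]4O[C@H](CO)[C@@H](O)[C@H]4O)c3n2)cc1` differs from compound 1 by 4-propoxyphenyl in place of 1,3-thiazol-5-yl on a carbon with a double bond to nitrogen. Because compound 2 gives 4.5 nM with a larger aromatic group, a modest gain is expected for compound 3, as the estimated step of a 2.2-fold lower number from compound 1 to compound 3 (0.34 log units; beyond the scatter). The estimate for compound 3 is 10 nM, ranging from 3 nM to 35 nM.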

Compound 3, inhibition constant: > 10000 nM
Compound 3: only a limit was reported; the forecaster's own chance of this, stated with the estimate: 2%; at least 1000-fold (3.00 log units) between middle value and limit.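

In this assay, 4-propoxyphenyl in place of 1,3-thiazol-5-yl on the carbon with a double bond to nitrogen gives an at least 450-fold higher number from compound 1 to compound 3 (2.65 log units; beyond the scatter). This position therefore does not accept every aromatic group, and one change here is enough to take binding from a measurable value to the top of the assay range. Compound 3 has only a limit, not a number, so the true size of the step stays unknown: the limit of > 10000 nM in this assay, at which 1 of the 3 values shown sits.

As far as these compounds go, whether the loss belongs to the phenyl ring or to the propoxy chain remains open. An unsubstituted phenyl group or a shorter methoxy chain at this place would separate the two.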